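A few compounds are considered here, and "the series" means these few. Any claim that something is new, unique, unknown or untested is made for them only; others in the source may bear on it.

Compound 1 `O=C(CO[C@H]1O[C@H](CO)[C@H](O)[C@H](O)[C@H]1O)NCc1cn(Cc2ccccc2)nn1`: 617 ug/mL
Compound 2 `C=CCCCCn1cc(CNC(=O)CO[C@H]2O[C@H](CO)[C@H](O)[C@H](O)[C@H]2O)nn1`: 394 ug/mL

In an ADME assay on HII4E cells (Mus musculus) for cytotoxicity, read by MTT assay, with a stated time of 48 h (on this read-out higher numbers stand for weaker inhibition and lower numbers for stronger inhibition), compound 1 gives 617 ug/mL. For the measured compounds named here, the only other measured compound, compound 2, gives 394 ug/mL, which lies within the scatter of that number.

Compound 3 `O=C(CO[C@H]1O[C@H](CO)[C@@H](O)[C@H](O)[C@H]1O)NCc1cn(Cc2ccccc2)nn1` is not yet measured. It relates to compound 1 as follows: the two compounds have the same atoms and bonds and differ only in configuration as drawn: 1 of 5 stereo elements differ; a stereocentre at a saturated ring carbon is drawn R in compound 1 and S in compound 3. No atoms leave or enter, and a stereocentre at a saturated ring carbon is drawn R in compound 1 and S in compound 3.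

Going by the values given here, the one measured step, a 1.6-fold lower number from compound 1 to compound 2 (0.19 log units; within the scatter), swaps phenyl for pent-4-en-1-yl and leaves configuration untouched, so it bears only indirectly. Among the compounds with values here, no measured pair tests a change of configuration. With so little evidence, no step beyond the scatter is expected in this assay.

The estimated step is a 1.1-fold lower number from compound 1 to compound 3 (0.03 log units; within the scatter). For compound 3 the expected value is 570 ug/mL, with an estimated range from 270 ug/mL to 1150 ug/mL.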

Compound 3, half-maximal inhibitory concentration: 193 ug/mL
Compound 3: middle estimate off by 3.0-fold (0.47 log units), on the high side; measured number below the stated range.
By their numbers in this assay, from the lowest: compound 3; then compounds 2 and 1 (each within the scatter of the next).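

Changing how one stereocentre is drawn is enough to move the number in this assay: a 3.2-fold lower number from compound 1 to compound 3 (0.50 log units; beyond the scatter). The earlier step, a 1.6-fold lower number from compound 1 to compound 2 (0.19 log units; within the scatter), replaced a whole group and stayed within the scatter, whereas this one replaces no atoms and still goes beyond it. The step can be assigned to this one saturated ring carbon, drawn R in compound 1 and S in compound 3, because nothing else separates the pair: the fact that compounds 1 and 3 differ only in the configuration as drawn

The compounds shown do not reveal whether the same inversion would have a similar effect with pent-4-en-1-yl in place of phenyl, or what inverting any of the other stereo elements would do. They also leave open how an amine or a carboxylic acid in place of phenyl would read in this assay.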